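The compounds below may be only part of what the source reports. "The series", "measured", "known", "first", "only" and "open" are said of these compounds alone.

Measured compounds:
Compound 1 `CCCCN(C)Cc1c(C(F)(F)F)nc2n(-c3c(C)cc(C)cc3C)c(Cl)cn12` gives 310 nM in an assay on cells for displacement of a labelled ligand from corticotropin-releasing factor receptor 1 (Homo sapiens), with a stated time of 100 min; on this read-out lower numbers stand for stronger inhibition and higher numbers for weaker inhibition.
Compound 2 `Cc1cc(C)c(-n2c(Cl)cn3c(CN(CCC(F)(F)F)Cc4ccc(Cl)cc4)c(C(F)(F)F)nc23)c(C)c1` gives 12 nM in this assay.

Within this pair, compound 1 stands at the higher of the two numbers; compound 2 sits at a markedly lower number, and the gap between the two is wider than the usual scatter of repeated runs. Among the compounds with values here, no step between two measured compounds that differ in only one place is available, so the two values can only be set side by side, not read as a single controlled change.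

The step now followed leads from compound 1 to compound 3 `Cc1cc(C)c(-n2c(Cl)cn3c(CN4CCC(C)CC4)c(C(F)(F)F)nc23)c(C)c1`, which is not yet measured in this assay. The change is 4-methylpiperidin-1-yl in place of butyl(methyl)amino on a saturated chain carbon bound to an aromatic carbon.

Within the data shown here, since no measured pair isolates this kind of change, the size of the step is expected with caution. Compound 3 is expected to land at 150 nM, with a range of 40 nM to 600 nM. The step from compound 1 to compound 3 is expected to be a modest drop in number, on the order of a 2.1-fold lower number from compound 1 to compound 3 (0.32 log units; beyond the scatter), though a result within the scatter would not surprise.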

Compound 3, inhibition constant: 3200 nM
Beside the measured number, compound 3's estimate is 21-fold (1.33 log units) below it, outside the stated range (above it).
By their numbers in this assay, from the lowest: compound 2; then compound 1; then compound 3.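

In this assay, within the data shown here, the open butyl(methyl)amino group gives way to the closed 4-methylpiperidin-1-yl group on a saturated chain carbon bound to an aromatic carbon, and this single change brings a 10-fold higher number from compound 1 to compound 3 (1.01 log units; beyond the scatter) and marks this place as one where the read-out responds strongly to the form of the amine, something the two earlier compounds could not show with no single-place step between them. The entering group brings one more heavy atom and a six-membered non-aromatic ring, while the counts of hydrogen-bond donors and acceptors and the net charge stay the same, so these counted features do not separate compound 1 from compound 3. No evidence at hand bears on why the number rises with this change.

From the compounds shown here alone, a plain piperidin-1-yl group at this place would separate the effect of the ring from that of its methyl, and that question stays open here. Also open, going by these compounds, are how a morpholin-4-yl group would fare at this place and which part of the amine in compound 2 goes with its value of 12 nM in this assay on this receptor.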